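This account rests on a few compounds, and the source may have more. Where it says the series, first, only, none or still open, it means among the compounds named here.

Values in a functional assay on HepG2 cells (Homo sapiens) for inhibition, read by MTT assay, with a stated time of 72 h (a higher number here means a weaker inhibitor, a lower number a stronger inhibitor), each one a limit of the assay:

- Compound 1 `CC(=O)Oc1cc(C(=O)C2=C(O)[C@]3(CC=C(C)C)C[C@@H](C/C=C(\C)CCC=C(C)C)[C@](C)(CCC=C(C)C)[C@](CC=C(C)C)(C2=O)C3=O)ccc1O`: > 20000 nM
- Compound 2 `CC(=O)Oc1ccc(C(=O)C2=C(O)[C@]3(CC=C(C)C)C[C@@H](C/C=C(\C)CCC=C(C)C)[C@](C)(CCC=C(C)C)[C@](CC=C(C)C)(C2=O)C3=O)cc1OC(C)=O`: > 20000 nM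
- Compound 3 `CC(C)=CCC/C(C)=C/C[C@@H]1C[C@]2(CC=C(C)C)C(=O)[C@@](CC=C(C)C)(C(=O)C(C(=O)c3ccc(OCC(=O)O)c(OCC(=O)O)c3)=C2O)[C@@]1(C)CCC=C(C)C`: > 20000 nM

Compound 3 gives only a limit, > 20000 nM, so there is no number to step from. The measured set shows (the limit of > 20000 nM in this assay, at which 3 of the 3 values shown sit).

Compound 4 `COC(=O)COc1ccc(C(=O)C2=C(O)[C@]3(CC=C(C)C)C[C@@H](C/C=C(\C)CCC=C(C)C)[C@](C)(CCC=C(C)C)[C@](CC=C(C)C)(C2=O)C3=O)cc1OCC(=O)O` differs from compound 3 by methyl in place of hydrogen on an oxygen next to a carbonyl group, which is carboxy to methoxycarbonyl. Going by the values given here, the only measured step is a step that the two limits leave unreadable from compound 1 to compound 2, for acetyl in place of hydrogen on an oxygen on an aromatic ring. Among the compounds with values here, it offers no size to carry over, and no measured compound shows a number in this assay. The expected change is a number no higher from compound 3 to compound 4 (the limit leaves the size open), with no step beyond the scatter expected in either direction. For compound 4 the estimated value is 20000 nM, with an expected range of 9000 nM to 40000 nM.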

Compound 4, half-maximal inhibitory concentration: > 20000 nM
Compound 4 was reported as a limit (the forecaster's own chance of this, stated with the estimate: 80%); the middle value lies on the limit itself.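

Compound 3 and compound 4 are both limits in this assay, so no step can be read between them: the limit of > 20000 nM in this assay, at which 4 of the 4 values shown sit.

The compounds shown leave open whether methyl in place of hydrogen, or any other change in this series, alters inhibition in this assay.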